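The source may hold more compounds than are shown below. What is called first, only, known or untested is meant among the compounds shown, and "the series" means these compounds.

Working notes on the step from compound 3 `C#CCSc1nc(Sc2nc3ccccc3s2)c(C#N)c(-c2cc(OC)c(OC)c(OC)c2)n1` to compound 4 `C#CCSc1nc(Sc2nc(C)cs2)c(C#N)c(-c2cc(OC)c(OC)c(OC)c2)n1`. In a functional assay on PC-9 cells (Homo sapiens) for antiproliferative activity, read by MTT assay (a lower number here means a stronger inhibitor, a higher number a weaker inhibitor), compound 3 gives > 20000 nM, a limit and not a number. Compound 1 `C#CCSc1nc(Sc2nc(C)c(C)s2)c(C#N)c(-c2cc(OC)c(OC)c(OC)c2)n1` gives > 20000 nM, also a limit. Compound 2 `C#CCSc1nc(Sc2ccccn2)c(C#N)c(-c2cc(OC)c(OC)c(OC)c2)n1` gives > 20000 nM, again a limit. The series therefore shows only (the limit of > 20000 nM in this assay, at which 3 of the 3 values shown sit).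

The change is 4-methyl-1,3-thiazol-2-yl in place of 1,3-benzothiazol-2-yl on a sulfur. Among the compounds with values here, three measured steps bear on it: a step that the two limits leave unreadable from compound 1 to compound 3, a step that the two limits leave unreadable from compound 2 to compound 3 and a step that the two limits leave unreadable from compound 1 to compound 2. None has a readable size, so none supports a move in either direction. No change beyond the scatter is expected, and the estimated step is a number no higher from compound 3 to compound 4 (the limit leaves the size open). For compound 4 the estimated value is 20000 nM, with an expected range of 8000 nM to 40000 nM.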

Compound 4, half-maximal inhibitory concentration: > 20000 nM
Compound 4: only a limit was reported (the forecaster's own chance of this, stated with the estimate: 85%); the middle value lies on the limit itself.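

Compound 4 gives > 20000 nM, a limit and not a number. Within the data shown here, no step linking compound 4 to compound 1, compound 2 or compound 3 can be read. The compounds shown leave open how the groups on the sulfur rank against one another: the limit of > 20000 nM in this assay, at which 4 of the 4 values shown sit.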